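Aryl exchange at the benzylamide end of the series

A few compounds are considered here, and "the series" means these few. Any claim that something is new, unique, unknown or untested is made for them only; others in the source may bear on it.

For the measured compounds named here, compound 2 `COc1ccccc1N1CCN(CCCCC(=O)NCc2ccccc2-c2c(OC)cccc2OC)CC1` holds the highest of the two numbers so far in an assay on CHO-K1 cells for displacement of a labelled ligand from 5-hydroxytryptamine receptor 7 (Homo sapiens), read by scintillation counting (a lower number here means a stronger inhibitor, a higher number a weaker inhibitor), where compound 2 gives 32.4 nM; its nearest neighbour is compound 1 `COc1ccccc1N1CCN(CCCCC(=O)NCc2ccccc2-c2ccc(Cl)cc2)CC1`, which in this assay gives 25.9 nM, a gap within the scatter. Going by the values given here, the only measured step, a 1.3-fold higher number from compound 1 to compound 2 (0.10 log units; within the scatter), is the replacement of 4-chlorophenyl by 2,6-dimethoxyphenyl on an aromatic carbon, and it is flat. Compound 3 `COc1ccccc1N1CCN(CCCCC(=O)NCc2ccccc2-c2ccccc2C)CC1` is not yet measured; it differs from compound 2 by 2-methylphenyl in place of 2,6-dimethoxyphenyl on an aromatic carbon. Among the compounds with values here, this is the same kind of change as the one step in hand, an exchange of one aryl group for another at the same aromatic carbon, ortho to a large group, and that step stayed within the scatter. Within the data shown here, no other measured step bears on it. The step expected in this assay is therefore none beyond the scatter: a 1.2-fold lower number from compound 2 to compound 3 (0.06 log units; within the scatter). Compound 3 is estimated at 28 nM in this assay, with a range from 12 nM to 70 nM.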

Compound 3, inhibition constant: 26.1 nM
Estimate against measurement, compound 3: 1.1-fold (0.03 log units) above; low and high end bracket the measured number.
By their numbers in this assay, from the lowest: compounds 1, 3 and 2 (each within the scatter of the next).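

In this assay, the exchange of 2,6-dimethoxyphenyl for 2-methylphenyl gives a 1.2-fold lower number from compound 2 to compound 3 (0.09 log units; within the scatter), so at this aromatic carbon, ortho to a large group, an aryl group with 7 heavy atoms and 0 hydrogen-bond acceptors reads the same as one with 10 heavy atoms and 2 hydrogen-bond acceptors. For the compounds shown here, the exchange of 4-chlorophenyl for 2-methylphenyl gives a 1.0-fold higher number from compound 1 to compound 3 (0.00 log units; within the scatter), so all three aryl groups now lie within the scatter of each other and no step at this position separates them. Nothing available explains why these exchanges leave the number flat.

Still open, on these data alone, is whether this flat reading holds for an aryl group carrying an amine or a carboxylic acid. Also open, as far as these compounds go, is what a longer chain in the linker would do in this assay.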